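The source may report more compounds than this note shows. Statements on the series, on what has been measured and on what is new or still open speak of the compounds shown alone.

Measured compounds:
- compound 1, `CCCOC(=O)c1[nH]c(COC(C)=O)c(C(=O)OC(C)(C)C)c1C`: 2700 nM
- compound 2, `CCN1CCC(OC(=O)c2[nH]cc(C(=O)OC(C)C(C)(C)C)c2C)C1`: 260 nM

Compound 1 stands at the higher of the two numbers in an assay on CHO cells for inhibition of metabotropic glutamate receptor 1 (Rattus norvegicus); on this read-out lower numbers stand for stronger inhibition and higher numbers for weaker inhibition: in that assay compound 1 gives 2700 nM, while compound 2 gives 260 nM, a gap that lies beyond the usual scatter. Within the data shown here, compound 2 differs from compound 1 in more than one place, so the two values show only their own difference and no single step.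

Compound 3, `CCCOC(=O)c1[nH]c(C(=O)OC)c(C(=O)OC(C)(C)C)c1C`, has not been measured. It differs from compound 1 in one place: methoxycarbonyl in place of acetoxymethyl on an aromatic carbon. Among the measured compounds shown here, no measured pair in this set shows the effect of that exchange, so any expectation rests on the general spread of the two numbers alone. The step is expected to be small, within or just beyond the scatter, with a slight lean towards a lower number, as a 1.4-fold lower number from compound 1 to compound 3 (0.13 log units; within the scatter). For compound 3 the estimate in this assay is therefore 2000 nM, with a likely range from 600 nM to 6000 nM.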

Compound 3, half-maximal inhibitory concentration: 3200 nM
Estimate against measurement, compound 3: 1.6-fold (0.20 log units) below; the range from low to high includes it.
By their numbers in this assay, from the lowest: compound 2; then compounds 1 and 3 (each within the scatter of the next).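

Among these compounds, on the aromatic carbon next to the ring nitrogen, methoxycarbonyl in place of acetoxymethyl gives a 1.2-fold higher number from compound 1 to compound 3 (0.07 log units; within the scatter) in this assay, the first single change in this set that can be read, and it leaves the two compounds within the scatter of each other. With the propoxycarbonyl, tert-butoxycarbonyl and methyl groups of the core of compound 1 held constant, this read-out does not tell apart the group of 5 heavy atoms and the group of 4 heavy atoms, neither of which has a ring and each of which counts 2 hydrogen-bond acceptors. No independent finding is available to explain this result.

What the compounds shown leave open is whether this aromatic carbon accepts groups of another kind, such as a carboxylic acid, an amine or a longer chain, as readily as these two. Among the compounds shown here, also open is which of its several differences from compound 1 goes with the value of compound 2, 260 nM, since no single step connects the two compounds.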